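Methyl on the outer ring: benzamide and sulfonamide pairs

The compounds below may be only part of what the source reports. "The series", "measured", "known", "first", "only" and "open" are said of these compounds alone.

Compound 1 `CC(C)S(=O)(=O)n1c(N)nc2ccc(NC(=O)c3ccccc3)cc21`: > 500000 nM
Compound 2 `Cc1ccc(C(=O)Nc2ccc3nc(N)n(S(=O)(=O)C(C)C)c3c2)cc1`: > 500000 nM
Compound 3 `CC(C)S(=O)(=O)n1c(N)nc2ccc(NS(=O)(=O)c3ccccc3)cc21`: 62000 nM

Of the compounds shown here, three have been measured in an ADME assay on HepG2 2.2.15 cells (Homo sapiens) for cytotoxicity, read by MTT assay, with a stated time of 6 h; on this read-out lower numbers stand for higher toxicity in this test and higher numbers for lower toxicity in this test. Compound 1 reaches only the limit of the test, > 500000 nM. Compound 2 likewise gives a limit, > 500000 nM. For the measured compounds named here, compound 3 is the only one with a number, 62000 nM, so that the limit of > 500000 nM in this assay, at which 2 of the 3 values shown sit, describes where the other two sit. Compound 2 differs from compound 1 by methyl in place of hydrogen on an aromatic carbon, and the resulting step that the two limits leave unreadable from compound 1 to compound 2 cannot be read, since both values are limits.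

Compound 4 `Cc1ccc(S(=O)(=O)Nc2ccc3nc(N)n(S(=O)(=O)C(C)C)c3c2)cc1` is not yet measured. Going by the values given here, it differs from compound 3 by methyl in place of hydrogen on an aromatic carbon, the same change as the one between compound 1 and compound 2, made on the same kind of place. The difference between the cores of compound 1 and compound 3 is not broken down here.

Among the compounds with values here, for compound 4 in this assay the expected step is a 1.1-fold lower number from compound 3 to compound 4 (0.05 log units; within the scatter), which rests on the fact that the only measured example of this change, a step that the two limits leave unreadable from compound 1 to compound 2, could not be sized, leaving no reason to expect a move beyond the usual scatter from compound 3. Compound 4 is therefore estimated at 55000 nM, with the range 15000 nM to 200000 nM.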

Compound 4, half-maximal cytotoxic concentration: 80000 nM
The estimate for compound 4 lay 1.5-fold (0.16 log units) below the measured number; the range from low to high includes it.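

In this assay, putting methyl in place of hydrogen on the aromatic ring of compound 3, which turns phenyl into 4-methylphenyl, gives a 1.3-fold higher number from compound 3 to compound 4 (0.11 log units; within the scatter), so on this core the two compounds cannot be told apart. For the compounds shown here, this is the only readable example of the change, and it shows only that on the core of compound 3 the methyl leaves the number inside the normal spread of repeated measurements. It does not show that the change behaves alike on both cores, because the matching pair, compound 1 and compound 2, gives only limits, so the step between them cannot be read and there is no second size to compare it with: the limit of > 500000 nM in this assay, at which 2 of the 4 values shown sit.

The compounds shown leave open whether any other group in the same place on the aromatic ring, such as an amine, a carboxylic acid or a longer chain like butyl, would move the number beyond the scatter on the core of compound 3. They also leave open whether the methyl has any size of effect at all on the core of compound 1, where both values rest at the limit of the test.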